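Carboxylic acid on the pyridine of an oxazole ketone

The source may report more compounds than this note shows. Statements on the series, on what has been measured and on what is new or still open speak of the compounds shown alone.

Measured compounds:
compound 1, `Nc1cccc(-c2cnc(C(=O)CCCCCCc3ccccc3)o2)c1`, 19 nM
compound 2, `NC(=O)c1cccc(-c2cnc(C(=O)CCCCCCc3ccccc3)o2)c1`, 6 nM
compound 3, `Cc1ccc(-c2cnc(C(=O)CCCCCCc3ccccc3)o2)nc1`, 2.8 nM

In an assay (Rattus norvegicus) for inhibition of Fatty-acid amide hydrolase 1 (Homo sapiens) (on this read-out lower numbers stand for stronger inhibition and higher numbers for weaker inhibition), compound 3 gives the lowest of the three numbers, with a 2.1-fold lower number from compound 2 to compound 3 (0.33 log units; beyond the scatter) and a 6.8-fold lower number from compound 1 to compound 3 (0.83 log units; beyond the scatter). Compound 4, `O=C(CCCCCCc1ccccc1)c1ncc(-c2ncccc2C(=O)O)o1`, carries 3-carboxypyridin-2-yl in place of 5-methylpyridin-2-yl on an aromatic carbon. Within the data shown here, no measured step covers a carboxyl group; the nearest guide is a 3.2-fold lower number from compound 1 to compound 2 (0.50 log units; beyond the scatter), which shows that a polar substituent on the aryl ring was tolerated there. The carboxyl is a new kind of group, so the expectation is uncertain and leans toward a higher number: compound 4 is expected at 25 nM, in the range 5 nM to 120 nM, meaning an expected step of an 8.9-fold higher number from compound 3 to compound 4 (0.95 log units; beyond the scatter).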

Compound 4, inhibition constant: > 50 nM
Compound 4: only a limit was reported (the forecaster's own chance of this, stated with the estimate: 3%); at least 2.0-fold (0.30 log units) between middle value and limit.
By their numbers in this assay, from the lowest: compound 3; then compound 2; then compound 1. At a limit, above all of these: compound 4.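

In this assay compound 4 gives only a limit, > 50 nM. With 3-carboxypyridin-2-yl on this aromatic carbon, the steps are an at least 17-fold higher number from compound 3 to compound 4 (1.25 log units; beyond the scatter), an at least 8.3-fold higher number from compound 2 to compound 4 (0.92 log units; beyond the scatter) and an at least 2.6-fold higher number from compound 1 to compound 4 (0.42 log units; beyond the scatter). This position therefore does not accept every substituted aryl group, and the gain seen with the carbamoyl group does not carry over to this carboxylic acid.

From the compounds shown here alone, how far compound 4 lies beyond its limit stays open. Also open, going by these compounds, is whether the loss belongs to the carboxylic acid itself or to its place on the pyridine, and whether a methyl ester there would behave alike.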